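The source may report more compounds than this note shows. Statements on the series, on what has been measured and on what is new or still open speak of the compounds shown alone.

Measured so far in a functional assay on isolated protein for agonist activity at Glucose-dependent insulinotropic receptor (Rattus norvegicus), read by HTRF and cAMP accumulation; a higher number here means a larger maximal response, a lower number a smaller maximal response:
compound 1, `CC1(OC(=O)N2CCC(O[C@H]3CC[C@H](Oc4cnc(S(C)(=O)=O)cn4)CC3)CC2)CC1`: 123%
compound 2, `CS(=O)(=O)c1cnc(O[C@H]2CC[C@H](OC3CCN(C(=O)OC4CCOC4)CC3)CC2)cn1`: 109%

Among the compounds with values here, compound 2 stands lowest of the two numbers in this assay; its nearest neighbour is compound 1, and the only measured step, a number 14 percentage points lower from compound 1 to compound 2 (beyond the scatter), separates the two. That step alters the group on the oxygen next to the carbonyl group, the same place that changes again on the way to compound 3, `CS(=O)(=O)c1cnc(O[C@H]2CC[C@H](OC3CCN(C(=O)Oc4ccccc4)CC3)CC2)cn1`: phenyl in place of oxolan-3-yl on an oxygen next to a carbonyl group. Within the data shown here, no measured pair sets phenyl against oxolan-3-yl at this place, so the earlier step gives only the scale of what one change here has done, not its direction. A step of modest size in this assay, in either direction or none beyond the scatter, is the reasonable expectation. Compound 3 is therefore expected to give about 110% in this assay, within 90% to 130%, which means an expected step of a number 1 percentage points higher from compound 2 to compound 3 (within the scatter).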

Compound 3, largest response reached (Emax), in percent of the reference or control that the assay uses: 104%
Compound 3: middle estimate off by 6 percentage points, on the high side, and the stated range covers the measured number.
By their numbers in this assay, from the lowest: compounds 3 and 2 (each within the scatter of the next); then compound 1.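

At the oxygen next to a carbonyl group, the aromatic phenyl and the non-aromatic oxolan-3-yl cannot be told apart in this assay (a number 5 percentage points lower from compound 2 to compound 3 (within the scatter)). Set against 1-methylcyclopropyl, the same place gives a step beyond the scatter (a number 19 percentage points lower from compound 1 to compound 3 (beyond the scatter)), so compound 2 and compound 3 now both stand apart from compound 1 while remaining level with each other. No measurement on hand accounts for this grouping.

From the compounds shown here alone, whether the higher response of compound 1 (123%) belongs to 1-methylcyclopropyl alone or extends to other saturated carbon groups, such as tert-butyl or cyclobutyl, remains open. Also open, going by these compounds, is whether a phenyl carrying fluorine or methoxy would stay level with the unsubstituted phenyl of compound 3.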